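Swapping Chloro for Bromo in Compound 1

This account rests on a few compounds, and the source may have more. Where it says the series, first, only, none or still open, it means among the compounds named here.

Measured so far:
Compound 1 `O=C(/C=C/c1ccc(F)c(Cl)c1)c1ccc(B(O)O)cc1` gives 25000 nM in a functional assay on MCF-10A cells (Homo sapiens) for inhibition; on this read-out higher numbers stand for weaker inhibition and lower numbers for stronger inhibition.
Compound 2 `O=C(O)COc1ccc(/C=C/C(=O)c2ccc(Cl)c(Cl)c2)cc1` gives 12000 nM in this assay.

Compound 1 stands at the higher of the two numbers, so it is the weaker inhibitor of the pair; compound 2 lies lower, a gap beyond the usual scatter. Compound 3 `O=C(/C=C/c1ccc(F)c(Br)c1)c1ccc(B(O)O)cc1` differs from compound 1 in a single place: bromo in place of chloro on an aromatic carbon. Among the compounds with values here, no measured pair shows this exchange, so the step is expected to be small, with no clear direction beyond the scatter: a 1.1-fold lower number from compound 1 to compound 3 (0.06 log units; within the scatter). Compound 3 is therefore estimated at 22000 nM, within 9000 nM to 55000 nM.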

Compound 3, half-maximal inhibitory concentration: 17000 nM
The estimate for compound 3 lay 1.3-fold (0.11 log units) above the measured number; the measured number falls inside the stated range.
By their numbers in this assay, from the lowest: compounds 2, 3 and 1 (each within the scatter of the next, the first and the last beyond it).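

In this assay bromo in place of chloro on this aromatic carbon gives a 1.5-fold lower number from compound 1 to compound 3 (0.17 log units; within the scatter) and so leaves the two halogens separated by no more than ordinary repeat variation. This first comparison that differs in one place shows that, on the core of compound 1, this exchange of one halogen for another does not produce a clear difference. Nothing available here accounts for this result.

As far as these compounds go, whether a group of another kind in this place, such as methyl, an amine or a nitrile, would give a number beyond the scatter remains open. So does whether the same exchange would give a similar result on the core of compound 2.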